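The compounds below may be only part of what the source reports. "The series", "measured", "known", "first", "only" and "open" are said of these compounds alone.

Among the compounds with values here, in a functional assay on Raji cells (Homo sapiens) for antiproliferative activity, read by MTT assay, with a stated time of 48 h (on this read-out higher numbers stand for weaker inhibition and lower numbers for stronger inhibition), compound 1 `CCN(CC)CCn1c(N)c(-c2nc3ccccc3[nH]2)c2nc(C#N)c(C#N)nc21` gives 8950 nM, the only actual number among the measured compounds. Compound 2 `CN1CCN(CCn2c(N)c(-c3nc4ccccc4[nH]3)c3nc(C#N)c(C#N)nc32)CC1` gives > 50000 nM, which is a limit of the assay. Compound 3 `N#Cc1nc2c(-c3nc4ccccc4[nH]3)c(N)n(CCCO)c2nc1C#N` gives > 50000 nM, again a limit. The two readable steps, an at least 5.5-fold higher number from compound 1 to compound 2 (0.74 log units; beyond the scatter) and an at least 5.5-fold higher number from compound 1 to compound 3 (0.74 log units; beyond the scatter), both replace the diethylamino group on the chain. Compound 4 `CCN(CC)CCn1c(N)c(-c2nc3ccccc3n2C)c2nc(C#N)c(C#N)nc21` keeps that group and differs elsewhere: methyl in place of hydrogen on an aromatic nitrogen. Neither step touches that place, so they offer only a loose guide, and a small move towards higher numbers in this assay is expected, perhaps none beyond the scatter. The expected change is a 1.5-fold higher number from compound 1 to compound 4 (0.16 log units; within the scatter). For compound 4 the estimated value is 13000 nM, with an expected range of 4000 nM to 45000 nM.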

Compound 4, half-maximal inhibitory concentration: 2080 nM
Estimate against measurement, compound 4: 6.3-fold (0.80 log units) above; measured number outside the range, below it.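

In this assay, the hydrogen on this aromatic nitrogen of the 1H-benzimidazol-2-yl group proves dispensable: with the diethylamino chain kept, methyl there gives a 4.3-fold lower number from compound 1 to compound 4 (0.63 log units; beyond the scatter). Within the data shown here, the earlier steps all changed the chain and moved towards higher numbers, so this is the only step at this position and the only one towards lower numbers. Nothing measured here accounts for this step. On these data alone, whether methyl would bring the same change with the chain of compound 2 or compound 3 stays open. So does the effect of an ethyl or benzyl group on this nitrogen.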